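The source may hold more compounds than are shown below. What is called first, only, known or untested is meant among the compounds shown, and "the series" means these compounds.

In a functional assay on SGC-7901 cells (Homo sapiens) for inhibition, read by MTT assay, with a stated time of 72 h (on this read-out higher numbers stand for weaker inhibition of growth and lower numbers for stronger inhibition of growth), compound 3 (`O[C@H](COCCOC[C@@H](O)Cc1cn(Cc2cccc(-c3ccccc3)c2)nn1)Cc1ccc(-c2ccccc2)cc1`) gives 10600 nM and stands level with compound 1 (`O[C@H](COCCOC[C@@H](O)Cc1cn(Cc2ccc3ccccc3c2)nn1)Cc1ccc(-c2ccccc2)cc1`) at 12100 nM on these numbers. Compound 2 (`COC1=C(OC)C(=O)C(CCCCCCCCCCn2cc(C[C@H](O)COCCOC[C@@H](O)Cc3ccc(-c4ccccc4)cc3)nn2)=C(C)C1=O`) reads 3800 nM in the same test. Compound 4 (`O[C@H](COCCOC[C@@H](O)Cc1cn(Cc2ccc(C(F)(F)F)cc2)nn1)Cc1ccc(-c2ccccc2)cc1`) has yet to be measured. It differs from compound 3 in one place (4-(trifluoromethyl)phenyl in place of 3-phenylphenyl on a saturated chain carbon bound to an aromatic nitrogen) where 4-(trifluoromethyl)phenyl stands in place of 3-phenylphenyl on a saturated chain carbon bound to an aromatic nitrogen. Among the compounds with values here, the one measured step at this place is small (a 1.1-fold lower number from compound 1 to compound 3 (0.06 log units; within the scatter)) and lies within the scatter. Compound 2 also differs at this place and reads lower, but its group there is unlike the one entering. The data therefore suggest no direction, and no step beyond the scatter is expected in this assay (a 1.0-fold higher number from compound 3 to compound 4 (0.02 log units; within the scatter)). For compound 4 the estimate is 11000 nM with an expected range of 5500 nM to 22000 nM on this read-out.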

Compound 4, concentration for 50% growth inhibition: 8700 nM
Beside the measured number, compound 4's estimate is 1.3-fold (0.10 log units) above it, within the range that was stated.
By their numbers in this assay, from the lowest: compound 2; then compounds 4, 3 and 1 (each within the scatter of the next).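

In this assay, the place on a saturated chain carbon bound to an aromatic nitrogen now carries a third group, and the numbers stay level (a 1.2-fold lower number from compound 3 to compound 4 (0.09 log units; within the scatter); a 1.4-fold lower number from compound 1 to compound 4 (0.14 log units; within the scatter)). The earlier pair compared only groups with two aromatic rings, whereas 4-(trifluoromethyl)phenyl has one such ring and brings in fluorine, so across compounds 1, 3 and 4 neither the second ring nor the swap to this group moves the number beyond the scatter. No measurement is at hand that would account for this.

The compounds shown leave open whether a group of another kind at this place, such as an amine or a carboxylic acid, would also read level with these three. They also leave open whether a plain phenyl, without trifluoromethyl, would do so.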